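Chloro for Hydrogen: One Change Measured Twice

The source may report more compounds than this note shows. Statements on the series, on what has been measured and on what is new or still open speak of the compounds shown alone.

Compound 1 `Nc1nc(N)nc(-c2ccccc2Br)n1`: 1.26
Compound 2 `Cc1c(N(C)C)c(=O)n(C)c(=O)n1-c1ccccc1`: 1.19
Compound 3 `Nc1nc(N)nc(-c2ccc(Cl)cc2Br)n1`: 2.09

In a physicochemical assay for lipophilicity (on this read-out higher numbers stand for higher lipophilicity and lower numbers for lower lipophilicity), compound 1 gives 1.26 and compound 3 gives 2.09. Between them lies one change, (chloro in place of hydrogen on an aromatic carbon), and it made a step of a number 0.83 log units higher from compound 1 to compound 3 (beyond the scatter). Compound 2 rests on a different core; the difference between the two cores is not broken down here. In this assay compound 2 gives 1.19, within the scatter of compound 1 and beyond the scatter below compound 3. Compound 4 `Cc1c(N(C)C)c(=O)n(C)c(=O)n1-c1ccc(Cl)cc1` has not yet been measured. It differs from compound 2 by chloro in place of hydrogen on an aromatic carbon. Among the compounds with values here, this is the same kind of change as the one between compound 1 and compound 3, not the same: in compound 4 the chloro stands para to a large group, whereas in compound 3 it stands meta to a bromo group and para to a group of 8 heavy atoms. Within the data shown here, for compound 4 a step of a number 0.76 log units higher from compound 2 to compound 4 (beyond the scatter) is expected, resting on the only comparable measured step, a number 0.83 log units higher from compound 1 to compound 3 (beyond the scatter). Compound 4 is therefore estimated at 1.95, between 1.6 and 2.3.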

Compound 4, partition coefficient: 2.32
Estimate against measurement, compound 4: 0.37 log units below; the whole stated range lies below it.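

In this assay, chloro in place of hydrogen on an aromatic carbon now gives a step of a number 1.13 log units higher from compound 2 to compound 4 (beyond the scatter) on one core, against a step of a number 0.83 log units higher from compound 1 to compound 3 (beyond the scatter) on the other, the first of these large and the second modest. The direction of the change therefore held on both cores, but two pairs do not settle whether its size carries from one core to another, and they establish no rule for the series. Nothing shown here explains why the two steps are not the same size.

The compounds shown leave open whether a third core would give a step in the same direction, since each core here supplies a single pair. They also leave open how the step would look if the entering group were fluoro, methoxy, an amine or a carboxylic acid rather than chloro.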